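Cyano in place of sulfamoyl on the shared core

The compounds below may be only part of what the source reports. "The series", "measured", "known", "first", "only" and "open" are said of these compounds alone.

In a functional assay on MDA-MB-435 cells (Homo sapiens) for antiproliferative activity, read by sulforhodamine B assay, with a stated time of 72 h (on this read-out higher numbers stand for weaker inhibition and lower numbers for stronger inhibition), compound 1 (`Fc1ccc(Nc2nncc3ccccc23)cc1`) reads 4 nM and compound 2 (`Cc1cc(NS(=O)(=O)c2ccc(Nc3nncc4ccccc34)cc2)no1`) reads 27 nM while compound 3 (`NS(=O)(=O)c1ccc(Nc2nncc3ccccc23)cc1`) reads 18 nM on the same core. Compound 3 thus stands level with compound 2 within the scatter, and its number is clearly higher than that of compound 1.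

The next structure, compound 4 (`N#Cc1ccc(Nc2nncc3ccccc23)cc1`), carries cyano in place of sulfamoyl on an aromatic carbon, para to a large group. Cyano itself has not been measured in this series, so any guide is indirect.

Within the data shown here, two measured steps bear on the change. Sulfamoyl in place of fluoro on an aromatic carbon gave a 4.5-fold higher number from compound 1 to compound 3 (0.65 log units; beyond the scatter) and is the closer guide, as it concerns the same place. Hydrogen in place of 5-methyl-1,2-oxazol-3-yl on a sulfonamide nitrogen gave a 1.5-fold lower number from compound 2 to compound 3 (0.18 log units; within the scatter) and says little about losing the sulfamoyl group as a whole.

Since compound 1 without sulfamoyl reads 4 nM there, a move towards a lower number is expected, smaller than the fluoro step. The expected change is a 2.3-fold lower number from compound 3 to compound 4 (0.35 log units; beyond the scatter) in the direction of stronger inhibition. In this assay compound 4 is estimated at 8 nM with a range of 3 nM to 22 nM for now.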

Compound 4, half-maximal inhibitory concentration: 2 nM
Compound 4: the middle estimate sits 4.0-fold (0.60 log units) above what was measured; the whole stated range lies above it.
By their numbers in this assay, from the lowest: compounds 4 and 1 (each within the scatter of the next); then compounds 3 and 2 (each within the scatter of the next).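

Cyano in place of sulfamoyl on an aromatic carbon, para to a large group, gives a 9.0-fold lower number from compound 3 to compound 4 (0.95 log units; beyond the scatter) in this assay, so the sulfamoyl penalty at this position is now seen from a second direction and does not depend on fluoro being the comparison group. Fluoro and cyano stand level here, with a 2.0-fold lower number from compound 1 to compound 4 (0.30 log units; within the scatter) as the printed step, which means this position holds two different non-sulfonamide groups at about the same low number, and both lie beyond the scatter from compound 3. The change takes away sulfamoyl, with 4 heavy atoms and 1 hydrogen-bond donor, and brings in cyano, with 2 heavy atoms and 0 hydrogen-bond donors, so size and donor count shift together and these compounds cannot separate them.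

As far as these compounds go, whether the low numbers extend to a methoxy group, a primary amine, a carboxylic acid or a plain hydrogen at this position remains open, as does whether a methylsulfonyl group, which has no sulfonamide nitrogen, would read like sulfamoyl or like cyano. Nothing available accounts for the difference between sulfamoyl and cyano at this position.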